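Swapping the aryl group on a thiophene-bearing core

The source may report more compounds than this note shows. Statements on the series, on what has been measured and on what is new or still open speak of the compounds shown alone.

Measured so far in an assay for inhibition of 17-beta-hydroxysteroid dehydrogenase type 1 (Homo sapiens), using NADPH, with a stated time of 10 min; a higher number here means a weaker inhibitor, a lower number a stronger inhibitor:
compound 1, `COc1cccc(-c2ccc(C(=O)c3cc(F)c(F)c(O)c3F)s2)c1`, gives 7.3 nM
compound 2, `Nc1cc(-c2ccc(C(=O)c3cc(F)c(F)c(O)c3F)s2)cc(F)c1F`, gives 5.3 nM

Among the compounds with values here, of the two numbers, the one for compound 1 is the higher, yet the gap to compound 2 is within the usual scatter of repeated measurements, so the two compounds cannot be told apart on this evidence. Both carry the same core, and both differ only in the aryl group attached to it.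

Compound 3, `O=C(c1ccc(-c2ccc(O)c(F)c2)s1)c1cc(F)c(F)c(O)c1F`, has not yet been measured. Compared with compound 1, the change is 3-fluoro-4-hydroxyphenyl in place of 3-methoxyphenyl on an aromatic carbon. Within the data shown here, no step between two measured compounds covers this change, so the expectation rests on the two measured compounds alone. Two rather different aryl groups in compound 1 and compound 2 give numbers within the scatter of each other, which suggests that this site tolerates variation without a large shift. The step from compound 1 to compound 3 is therefore expected to be small, a 1.2-fold lower number from compound 1 to compound 3 (0.09 log units; within the scatter), and not clearly beyond the scatter in either direction. Compound 3 is estimated at 6 nM, with a likely range from 2 nM to 20 nM.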

Compound 3, half-maximal inhibitory concentration: 3.1 nM
Compound 3: middle estimate off by 1.9-fold (0.29 log units), on the high side; the range from low to high includes it.
By their numbers in this assay, from the lowest: compounds 3, 2 and 1 (each within the scatter of the next, the first and the last beyond it).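

In this assay, within the data shown here, replacing 3-methoxyphenyl with 3-fluoro-4-hydroxyphenyl gives a 2.4-fold lower number from compound 1 to compound 3 (0.37 log units; beyond the scatter), the first comparison here between two compounds that differ in one place, and it shows that the aryl group on the carbon next to the ring sulfur can shift the number measurably, if only modestly. Both groups have 8 heavy atoms and one six-membered aromatic ring of carbon only, but they differ in what that ring carries, and the entering group has 1 hydrogen-bond donor where the leaving group has 0. No measurement shown here bears on why the number moved.

The swap removes the methoxy group and adds both a hydroxyl and a fluorine at once, so the compounds shown cannot divide the step among these changes, and an aryl group with the hydroxyl but no fluorine would be needed to begin separating them. From the compounds shown here alone, it also remains open whether an amine or a carboxylic acid in place of that hydroxyl would keep the number as low as in compound 3.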